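The source may hold more compounds than are shown below. What is called first, only, known or untested is meant among the compounds shown, and "the series" means these compounds.

Compound 1 `CC(O)C1C(=O)NC1OC(=O)/C=C/c1ccc(Cl)cc1` and compound 2 `COc1ccc(/C=C/C(=O)OC2NC(=O)C2C(C)O)cc1` share one core and differ only at a single aromatic carbon. In a functional assay on MCF7 cells (Homo sapiens) for inhibition, read by MTT assay (a lower number here means a stronger inhibitor, a higher number a weaker inhibitor), compound 1 gives 1590 nM, and in this assay compound 2 gives 1590 nM. The step of no change at the digits printed from compound 1 to compound 2 (within the scatter) therefore lies within the scatter, so compound 2 stands level with compound 1 on these numbers, and neither can be called the stronger.

Compound 3 `CC(O)C1C(=O)NC1OC(=O)/C=C/c1ccc(Br)cc1` is not yet measured. It differs from compound 2 by bromo in place of methoxy on an aromatic carbon. For the measured compounds named here, the only step that bears on this change is no change at the digits printed from compound 1 to compound 2 (within the scatter), which showed that exchanging one small group at this carbon for another left this assay unchanged within the scatter. On that basis compound 3 is expected to show no step beyond the scatter, that is no change at the digits printed from compound 2 to compound 3 (within the scatter). The estimate for compound 3 in this assay is 1590 nM, with a range from 800 nM to 3200 nM.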

Compound 3, half-maximal inhibitory concentration: 1590 nM
Compound 3: middle estimate and measured number agree at the digits printed; measured number inside the range.
By their numbers in this assay, from the lowest: compounds 1, 2 and 3 (each within the scatter of the next).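

With bromo in place of methoxy on this aromatic carbon, this assay shows no change at the digits printed from compound 2 to compound 3 (within the scatter), and with bromo in place of chloro it shows no change at the digits printed from compound 1 to compound 3 (within the scatter). The position, para to a large group, has now carried three groups, chloro, methoxy and bromo, and the exchange of one halogen for another joins the two exchanges of a halogen for methoxy in leaving the read-out level, so this holds for all three pairs among these compounds. No evidence is available here on why the three compounds stand level.

The compounds shown leave open whether an amine, a carboxylic acid or a longer chain such as butoxy on this same carbon would also stand level with these three. They also leave open whether a change elsewhere on the shared core would move the read-out in this assay.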